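Working notes: chloro-to-hydrogen step and partition coefficient

The source may hold more compounds than are shown below. What is called first, only, known or untested is meant among the compounds shown, and "the series" means these compounds.

Measured so far in a physicochemical assay for lipophilicity; a higher number here means a more lipophilic compound, a lower number a more polar compound:

compound 1, `O=C1/C(=C/c2ccccc2)CCC/C1=C\c1cccc([N+](=O)[O-])c1`, gives 5.06
compound 2, `O=C1/C(=C/c2ccc(Cl)cc2)CCC/C1=C\c1ccccc1[N+](=O)[O-]`, gives 4.86
compound 3, `O=C1/C(=C/c2ccc(Cl)cc2)CCC/C1=C\c1cccc([N+](=O)[O-])c1`, gives 5.06

Compound 3 and compound 1 differ in one place, (hydrogen in place of chloro on an aromatic carbon), and the measured step is no change at the digits printed from compound 3 to compound 1 (within the scatter). Compound 2 and compound 3 are built from the same atoms joined differently; the difference between the two cores is not broken down here. In this assay compound 2 and compound 1 lie within the scatter of each other, and compound 2 and compound 3 likewise lie within the scatter of each other, so no order among the three is claimed.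

Not yet measured is compound 4, `O=C1/C(=C/c2ccccc2)CCC/C1=C\c1ccccc1[N+](=O)[O-]`. It stands to compound 2 as compound 1 stands to compound 3: the difference is hydrogen in place of chloro on an aromatic carbon, and the place line reads the same word for word as for the change from compound 3 to compound 1, so it is the same change, made on the core of compound 2 instead of the core of compound 3. Among the compounds shown it occurs twice in all.

Because the measured step of no change at the digits printed from compound 3 to compound 1 (within the scatter) stays within the scatter, the step from compound 2 to compound 4 in this assay is expected to be no change at the digits printed from compound 2 to compound 4 (within the scatter), of the same size as the earlier one. On that basis compound 4 is estimated at 4.86, with a range from 4.5 to 5.2.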

Compound 4, partition coefficient: 4.86
For compound 4 middle estimate and measured number coincide at the digits printed; measured number inside the range.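

In this assay the new step reads no change at the digits printed from compound 2 to compound 4 (within the scatter) and the earlier one reads no change at the digits printed from compound 3 to compound 1 (within the scatter), and with both inside the scatter the change from 4-chlorophenyl to phenyl leaves no readable mark on the core of compound 2 or on the core of compound 3. This is agreement between two small steps on two cores: it shows that a null result carried over in this one case, but it does not show that a step of any definite size would carry over, and it supports no rule beyond these four compounds. No measurement at hand accounts for the result.

The compounds shown leave open whether a group other than chloro on the same aromatic carbon, such as an amine, a carboxylic acid or a longer chain, would give a step beyond the scatter, and whether such a step would then read the same on both cores. They also leave open whether the change from 4-chlorophenyl to phenyl reads the same on any core other than those of compound 2 and compound 3.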